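This account rests on a few compounds, and the source may have more. Where it says the series, first, only, none or still open, it means among the compounds named here.

Measured compounds:
compound 1, `COc1ccc(OC)c(/C=C/c2nnc(Nc3ccc(Cl)cc3)o2)c1` — > 100000 nM
compound 2, `COc1ccc(OC)c(/C=C/C(=O)N/N=C/c2ccc(Cl)cc2)c1` — > 100000 nM

In a functional assay on Malme-3M cells (Homo sapiens) for antiproliferative activity, read by sulforhodamine B assay, with a stated time of 48 h (a higher number here means that more compound is tolerated, a lower number that less compound is tolerated), compound 1 gives > 100000 nM, which is a limit of the assay and not a number. In this assay compound 2 gives > 100000 nM, again a limit rather than a measured number. Compound 2 thus stands at the limit of > 100000 nM in this assay, at which 2 of the 2 values shown sit; no ranking between the two is possible from such values.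

Compound 3, `COc1ccc(OC)c(/C=C/C(=O)N/N=C/c2ccccc2)c1`, has not yet been tested in this assay. It differs from compound 2 in one place: hydrogen in place of chloro on an aromatic carbon, para to a large group. Among the compounds with values here, no step between two measured compounds is available here, so the expected size rests only on where compound 2 stands. Compound 2 shows only a limit, so no direction can be read from the numbers, and the expectation is no change beyond the usual scatter, with compound 3 most likely reported as a limit as well. Compound 3 is expected to give about 100000 nM in this assay, within 30000 nM to 300000 nM. The expected step is a number no higher from compound 2 to compound 3 (the limit leaves the size open).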

Compound 3, concentration lethal to 50% of the cells: > 100000 nM
Compound 3 was reported as a limit; the forecaster's own chance of this, stated with the estimate: 85%; the middle value lies on the limit itself.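

Within the data shown here, compound 2 and compound 3 are both reported only as limits in this assay, so the change from 4-chlorophenyl to phenyl gives no step that can be read. The compounds shown leave open how they rank against one another and which structural change would give a measured number, with all of them at one value: the limit of > 100000 nM in this assay, at which 3 of the 3 values shown sit.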